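Trimming a fused ring on a deubiquitinase inhibitor

The source may hold more compounds than are shown below. What is called first, only, known or untested is meant among the compounds shown, and "the series" means these compounds.

Of the compounds shown here, three have been measured in an assay on isolated protein for inhibition of ubiquitin carboxyl-terminal hydrolase 7 (Homo sapiens), read by fluorescence, with stated times of 30 min and 1 h (a lower number here means a stronger inhibitor, a higher number a weaker inhibitor), and share one core. Compound 1 `Cc1cc(Cl)cc(-c2ccnc3cc(CN4C(=O)CCC4=O)sc23)c1O[C@H]1C[C@H](N)C1` gives 3.4 nM. Within the data shown here, compound 2 `Cc1cc(Cl)cc(-c2ccnc3cc(CN4C(=O)CCC4=O)sc23)c1CN1[C@@H](C)CNC[C@@H]1C` gives 0.32 nM, and the only measured single-point step is an 11-fold lower number from compound 1 to compound 2 (1.03 log units; beyond the scatter). Compound 3 `Cc1cc(Cl)cc(-c2ccnc3cc(CN4C(=O)C5CC5C4=O)sc23)c1O[C@@H]1CCNC[C@@H]1C` gives 1.1 nM, the second highest of the three numbers, standing beyond the scatter from both compound 1 and compound 2.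

Compound 4 `Cc1cc(Cl)cc(-c2ccnc3cc(CN4C(=O)CCC4=O)sc23)c1O[C@@H]1CCNC[C@@H]1C` differs from compound 3 in one place: a group of 7 heavy atoms (4 carbon, 1 nitrogen, 2 oxygen; one five-membered non-aromatic ring with 1 hetero atom) in place of a group of 8 heavy atoms (5 carbon, 1 nitrogen, 2 oxygen; one three-membered non-aromatic ring of carbon only, one five-membered non-aromatic ring with 1 hetero atom), on a saturated chain carbon bound to an aromatic carbon. Among the measured compounds shown here, no measured step touches this part of the molecule; the one measured step concerns a different position and so does not bear on it. With nothing pointing either way, the step of a 1.1-fold lower number from compound 3 to compound 4 (0.04 log units; within the scatter) is expected to stay within the scatter. Compound 4 is accordingly estimated at 1 nM, with a range from 0.45 nM to 2.5 nM.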

Compound 4, half-maximal inhibitory concentration: 2.1 nM
Estimate against measurement, compound 4: 2.1-fold (0.32 log units) below; low and high end bracket the measured number.
By their numbers in this assay, from the lowest: compound 2; then compounds 3, 4 and 1 (each within the scatter of the next, the first and the last beyond it).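

Trimming the three-membered carbon ring back to plain 2,5-dioxopyrrolidin-1-yl gives a 1.9-fold higher number from compound 3 to compound 4 (0.28 log units; within the scatter), so the fused ring brings no clear change at this position. Among these compounds, at the other end of the molecule, 3-methylpiperidin-4-yl in place of 3-aminocyclobutyl gives a 1.6-fold lower number from compound 1 to compound 4 (0.21 log units; within the scatter), while (3-methylpiperidin-4-yl)oxy in place of (2,6-dimethylpiperazin-1-yl)methyl gives a 6.6-fold higher number from compound 2 to compound 4 (0.82 log units; beyond the scatter), the only new step beyond the scatter. Nothing available explains these steps.

Open, from the compounds shown here alone, is whether a fused four-membered carbon ring or two methyl groups on the 2,5-dioxopyrrolidin-1-yl would move the number beyond the scatter. Also open, going by these compounds, is whether the three-membered ring would behave alike alongside (2,6-dimethylpiperazin-1-yl)methyl.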